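The compounds below may be only part of what the source reports. "The series", "measured", "known", "first", "only" and "open" are said of these compounds alone.

Measured in a functional assay for inhibition, read by fluorescence and spectrophotometry, with a stated time of 30 h; a higher number here means a weaker inhibitor, a lower number a stronger inhibitor:
- compound 1 `COc1ccc(-c2cc(=O)c3ccc(OCCCCN4CCC(C)CC4)cc3o2)cc1`: 48200 nM
- compound 2 `COc1ccc(-c2cc(=O)c3ccc(OCCCCCN4CCC(C)CC4)cc3o2)cc1`: 55100 nM
- compound 3 `COc1ccc(-c2cc(=O)c3ccc(OCCCCCN4CCC(CCO)CC4)cc3o2)cc1`: 49400 nM

Compound 3 cannot be separated from the other two, with a 1.0-fold higher number from compound 1 to compound 3 (0.01 log units; within the scatter) and a 1.1-fold lower number from compound 2 to compound 3 (0.05 log units; within the scatter). Compound 4 `COc1ccc(-c2cc(=O)c3ccc(OCCCCCCN4CCC(CCO)CC4)cc3o2)cc1` carries one change from compound 3: (4-(2-hydroxyethyl)piperidin-1-yl)methyl in place of 4-(2-hydroxyethyl)piperidin-1-yl on a saturated chain carbon, five bonds along the chain from an oxygen on an aromatic ring. This places (4-(2-hydroxyethyl)piperidin-1-yl)methyl in place of 4-(2-hydroxyethyl)piperidin-1-yl, on a saturated chain carbon, five bonds along the chain from an oxygen on an aromatic ring. For the measured compounds named here, the closest precedent is the same kind of swap with 4-methylpiperidin-1-yl, four bonds along the chain, which gave a 1.1-fold higher number from compound 1 to compound 2 (0.06 log units; within the scatter). That is a single precedent, so the expectation is only tentative. No shift beyond the scatter is expected, with an estimated 1.1-fold lower number from compound 3 to compound 4 (0.02 log units; within the scatter). The estimate for compound 4 is 47000 nM, with an expected range of 23000 nM to 95000 nM.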

Compound 4, half-maximal inhibitory concentration: 50400 nM
For compound 4 the middle estimate is 1.1-fold (0.03 log units) below the measured one; the range from low to high includes it.
By their numbers in this assay, from the lowest: compounds 1, 3, 4 and 2 (each within the scatter of the next).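

In this assay, one more chain carbon makes no readable difference with the 4-(2-hydroxyethyl)piperidin-1-yl group either, with a 1.0-fold higher number from compound 3 to compound 4 (0.01 log units; within the scatter). On this longer chain, the 2-hydroxyethyl group in place of methyl also stays within the scatter, with a 1.1-fold lower number from compound 2 to compound 4 (0.04 log units; within the scatter), and so do both changes together, with a 1.0-fold higher number from compound 1 to compound 4 (0.02 log units; within the scatter). The swap of methyl for 2-hydroxyethyl now reads alike at two chain lengths: the same change on two cores in this assay, a 1.0-fold higher number (0.01 log units; within the scatter) from compound 1 to compound 3 and a 1.1-fold lower number (0.04 log units; within the scatter) from compound 2 to compound 4, 1.1-fold (0.05 log units) apart, within the scatter of two such steps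

Still open, as far as these compounds go, is whether any group here can move the number. A much shorter chain, or a carboxylic acid or morpholine at the chain end, might show that.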